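Acetyl in place of methoxy: the step to compound 4

A few compounds are considered here, and "the series" means these few. Any claim that something is new, unique, unknown or untested is made for them only; others in the source may bear on it.

In a functional assay (mast cells) for inhibition, with Rattus norvegicus as the target (a higher number here means that more compound is needed for the effect, a lower number that less compound is needed), three compounds sharing one core have been measured so far. Compound 1 `CC1CC/C(=N\Nc2ccccc2F)c2ncc(C(=O)O)c(=O)n21` gives 1200 nM, compound 2 `COc1ccc(N/N=C2\CCC(C)n3c2ncc(C(=O)O)c3=O)cc1` gives 128000 nM and compound 3 `Cc1cccc(N/N=C2\CCC(C)n3c2ncc(C(=O)O)c3=O)c1` gives 72900 nM. Compound 2 sits with compound 3 at the upper end of these numbers, and the gap between them is small: a 1.8-fold lower number from compound 2 to compound 3 (0.24 log units; within the scatter). Compound 1 stands well apart, with a 110-fold higher number from compound 1 to compound 2 (2.03 log units; beyond the scatter) and a 61-fold higher number from compound 1 to compound 3 (1.78 log units; beyond the scatter).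

Compound 4 `CC(=O)c1ccc(N/N=C2\CCC(C)n3c2ncc(C(=O)O)c3=O)cc1` keeps the core of compound 2 and changes one group: acetyl in place of methoxy on an aromatic carbon. Acetyl replaces methoxy on an aromatic carbon, para to a large group. Among the compounds with values here, no measured step makes this exchange. The nearest evidence is the swap of 4-methoxyphenyl for 3-methylphenyl, which stayed within the scatter. The two large steps both start from the 2-fluorophenyl of compound 1, which compound 4 lacks, so they set no expected size here, although they do argue for a wide range. No shift beyond the scatter is expected in either direction in this assay. The expected change is a 1.4-fold lower number from compound 2 to compound 4 (0.15 log units; within the scatter). Compound 4 is estimated at 90000 nM, with an expected range of 20000 nM to 300000 nM.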

Compound 4, half-maximal effective concentration: 8100 nM
Compound 4: middle estimate off by 11-fold (1.05 log units), on the high side; measured number below the stated range.
By their numbers in this assay, from the lowest: compound 1; then compound 4; then compounds 3 and 2 (each within the scatter of the next).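

In this assay, this position is far from indifferent to the group it carries: acetyl in place of methoxy on an aromatic carbon, para to a large group, gives a 16-fold lower number from compound 2 to compound 4 (1.20 log units; beyond the scatter). The earlier step without the 2-fluorophenyl, a 1.8-fold lower number from compound 2 to compound 3 (0.24 log units; within the scatter), stayed within the scatter, and every large step started from compound 1, so a large shift now appears in a pair where neither compound has that 2-fluorophenyl. Compound 4 falls between compound 1 and the pair of compounds 3 and 2 in the order of numbers, while the count of hydrogen-bond acceptors and donors is the same for methoxy and acetyl, so those counts do not separate the two groups. No measurement at hand explains the size of this step.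

From the compounds shown here alone, whether the step belongs to acetyl alone remains open, and a nitrile, a carboxylic acid or a primary amide on the same aromatic carbon would show how far it extends. Also open, going by these compounds, is how acetyl at this place would behave together with a fluorine on the same aromatic ring, as a second change to the core of compound 4.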